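Amine substituent change: carboxymethyl in place of butyl

The compounds below may be only part of what the source reports. "The series", "measured", "known", "first", "only" and "open" are said of these compounds alone.

Measured so far:
compound 1 `N#Cc1ccc(N[C@@H]2CN[C@H](C(=O)N3CCSC3)C2)cc1` — 33.6 nM
compound 2 `CCCCN(Cc1ccc(C#N)cc1)[C@@H]1CN[C@H](C(=O)N2CCSC2)C1` — 5 nM

In an assay on a cell-free system (plasma) for inhibition of Dipeptidyl peptidase 4 (Rattus norvegicus), read by fluorescence (a lower number here means a stronger inhibitor, a higher number a weaker inhibitor), compound 2 gives 5 nM, the lowest of the two numbers. Compound 1 gives 33.6 nM in this assay, a higher number beyond the scatter.

Compound 3 `N#Cc1ccc(CN(CC(=O)O)[C@@H]2CN[C@H](C(=O)N3CCSC3)C2)cc1` differs from compound 2 by carboxy in place of propyl on a saturated chain carbon bound to an amine nitrogen, that is, butyl to carboxymethyl on the amine. Among the compounds with values here, no measured pair in the set shows this change, so its size is uncertain. The step from compound 2 to compound 3 is expected to be a moderate rise in this assay, a 3.0-fold higher number from compound 2 to compound 3 (0.48 log units; beyond the scatter), beyond the scatter but short of the gap to compound 1. Compound 3 is estimated at 15 nM, within 3 nM to 80 nM.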

Compound 3, half-maximal inhibitory concentration: 16.3 nM
Compound 3: the middle estimate sits 1.1-fold (0.04 log units) below what was measured; the range from low to high includes it.
By their numbers in this assay, from the lowest: compound 2; then compound 3; then compound 1.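

In this assay the change from butyl to carboxymethyl on the amine gives a 3.3-fold higher number from compound 2 to compound 3 (0.51 log units; beyond the scatter) and so costs only a modest step beyond the scatter. A chain ending in a carboxylic acid is thus accepted at this amine nitrogen, with compound 3 still at 16.3 nM in this one pair. Nothing available gives a reason for the size of this step.

Open, from the compounds shown here alone, is whether the methyl ester or primary amide of that acid would stay nearer compound 2. Also open, going by these compounds, is how a longer chain carrying the acid, or a terminal amine, would read.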